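Removing a Core Methyl from a Saturated-Chain Analogue

The source may report more compounds than this note shows. Statements on the series, on what has been measured and on what is new or still open speak of the compounds shown alone.

The four compounds share one core carrying a long chain and are compared in a functional assay on MCF7 cells (Homo sapiens) for antiproliferative activity, read by MTT assay; a lower number here means a stronger inhibitor, a higher number a weaker inhibitor. Compound 1 `CCCC/C=C\CCCCCCCCCc1cc(=O)c2c(O)cc(O)c(C)c2o1` gives 17500 nM in this assay. Compound 2 `CCCC/C=C\CCCCCCCCCc1cc(=O)c2c(O)c(C)c(O)c(C)c2o1` carries a further methyl on the core, and in this assay compound 2 reaches only the limit > 67200 nM. The change from compound 2 to compound 1 is hydrogen in place of methyl on an aromatic carbon, and it made an at least 3.8-fold lower number from compound 2 to compound 1 (0.58 log units; beyond the scatter).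

Compound 3 `CCCCCCCCCCCCCCCc1cc(=O)c2c(O)c(C)c(O)c(C)c2o1` differs from compound 2 in the chain, (hexyl in place of hex-1-en-1-yl on a saturated chain carbon, nine bonds along the chain from an aromatic carbon). In this assay compound 3 likewise stands at the limit > 67200 nM. The step that the two limits leave unreadable from compound 2 to compound 3 cannot be sized because of the limit of > 67200 nM in this assay, at which 2 of the 3 values shown sit.

Compound 4 `CCCCCCCCCCCCCCCc1cc(=O)c2c(O)c(C)c(O)cc2o1` has not yet been measured. It arises from compound 3 by hydrogen in place of methyl on an aromatic carbon. This is the same kind of change as that from compound 2 to compound 1, but not the same: there the hydrogen entered ortho to two hydroxy groups and para to a fused ring, whereas here it enters ortho to a fused ring and to one hydroxy group and para to a hydroxy group. For compound 4 the expected step is an at least 2.2-fold lower number from compound 3 to compound 4 (0.35 log units; beyond the scatter), which rests on an at least 3.8-fold lower number from compound 2 to compound 1 (0.58 log units; beyond the scatter) and is uncertain since its starting point is a limit. In this assay compound 4 is estimated at 30000 nM, with a likely range from 8000 nM to 90000 nM, and a fair chance that only a limit is again returned.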

Compound 4, half-maximal inhibitory concentration: 43200 nM
For compound 4 the middle estimate is 1.4-fold (0.16 log units) below the measured one; low and high end bracket the measured number.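

In this assay, hydrogen in place of methyl on an aromatic carbon of the saturated-chain core gave an at least 1.5-fold lower number from compound 3 to compound 4 (0.19 log units; that floor lies within the scatter), so the removal of this methyl group moved the series from a limit to a readable number here as well. Both steps on the shared core run toward a lower number, even though the methyl group leaves a different aromatic carbon in each case, but this shows only a shared direction and not a shared size: the same change on two cores in this assay, an at least 3.8-fold lower number (0.58 log units; beyond the scatter) from compound 2 to compound 1 and an at least 1.5-fold lower number (0.19 log units; that floor lies within the scatter) from compound 3 to compound 4; the limit leaves it open whether they differ. The true size of neither step can be read, and the new step alone would not establish a change beyond the scatter, since both steps start from a limit: the limit of > 67200 nM in this assay, at which 2 of the 4 values shown sit.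

The compounds shown cover only methyl and hydrogen at these aromatic carbons, so it remains open how an ethyl group, a methoxy group or a fluorine atom there would read in this assay. For the compounds shown here, they also cover only two chains of one length, leaving open whether the same change would carry over to a core bearing a shorter chain, a longer chain or a chain ending in a carboxylic acid.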